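A Smaller Halogenated Ring: Expected Seizure Protection

A few compounds are considered here, and "the series" means these few. Any claim that something is new, unique, unknown or untested is made for them only; others in the source may bear on it.

Compound 1 `CN1CCN(CCCCOc2ccccc2/C=C/c2cccc(Cl)c2)CC1` — 0%
Compound 2 `CN1CCN(CCCCOc2ccccc2/C=C/c2ccc(Cl)c(Cl)c2)CC1` — 0%
Compound 3 `CN1CCN(CCCCOc2ccccc2/C=C/c2ccccc2F)CC1` — not yet measured

In a functional assay on the whole organism with Mus musculus as the target, in the maximal electroshock model, at a dose of 50 mg/kg by the oral route (a lower number here means less inhibition, a higher number more inhibition at the dose given (going by the name of the read-out)), compound 1 gives 0% and compound 2 gives 0%. Going by the values given here, compound 2 therefore stands level with compound 1, the only other measured compound, and the single measured step, no change at the digits printed from compound 1 to compound 2 (within the scatter), shows that a chloro in place of hydrogen on an aromatic carbon left the read-out unchanged within the scatter.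

Compound 3 differs from compound 2 in one place: 2-fluorophenyl in place of 3,4-dichlorophenyl on a double-bonded chain carbon bound to a double-bonded chain carbon. Among the compounds with values here, no measured step covers the exchange of one halogenated ring for another, so the only guide is that both measured compounds show no inhibition at all. On that basis the expected step is no change at the digits printed from compound 2 to compound 3 (within the scatter), none beyond the scatter. Compound 3 is accordingly estimated at 0%, with a range from 0% to 15%.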

Compound 3, a percentage reported as inhibition, in the whole organism at one dose (the size of the read-out at that dose, not a potency): 0%
Compound 3: the middle estimate sits on the measured number at the digits printed; measured number inside the range.
By their numbers in this assay, from the lowest: compounds 1, 2 and 3 (each within the scatter of the next).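

In this assay, replacing the 3,4-dichlorophenyl group with 2-fluorophenyl on a double-bonded chain carbon bound to a double-bonded chain carbon gives no change at the digits printed from compound 2 to compound 3 (within the scatter), and replacing 3-chlorophenyl with the same group gives no change at the digits printed from compound 1 to compound 3 (within the scatter). Going by these compounds alone, the earlier pair showed only that adding a chloro group left the read-out level, whereas these steps show the same for a ring carrying fluorine instead of chlorine. No supporting measurement is available to explain this flat result.

With all three values level, the compounds cannot show whether this position matters for protection or whether the shared core gives none at this dose, whatever the ring carries. A phenyl ring bearing an amine or a carboxylic acid, or a longer chain elsewhere in the core, remains an open test.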